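Furan for thiophene on the saturated ring carbon

The compounds below may be only part of what the source reports. "The series", "measured", "known", "first", "only" and "open" are said of these compounds alone.

Compound 1 `COc1cc(C(=O)C2Sc3nnc(-c4cc(OC)c(OC)c(OC)c4)n3NC2c2ccco2)cc(OC)c1OC` in a functional assay on MCF7 cells (Homo sapiens) for cytotoxicity, read by MTT assay, with a stated time of 48 h (a higher number here means a weaker inhibitor, a lower number a stronger inhibitor), gives only a limit, > 100000 nM.
Compound 2 `COc1cc(-c2nnc3n2NC(c2ccco2)C(C(=O)c2cccs2)S3)cc(OC)c1OC` gives only a limit, > 100000 nM.
Compound 3 `COc1cc(-c2nnc3n2NC(c2cccs2)C(C(=O)c2ccccc2)S3)cc(OC)c1OC` gives only a limit, > 100000 nM.

Compound 3 therefore stands at the limit of > 100000 nM in this assay, at which 3 of the 3 values shown sit, with no number of its own. Compound 4 `COc1cc(-c2nnc3n2NC(c2ccco2)C(C(=O)c2ccccc2)S3)cc(OC)c1OC` differs from it in one place: furan-2-yl in place of thiophen-2-yl on a saturated ring carbon. Among the compounds with values here, the only measured step, a step that the two limits leave unreadable from compound 1 to compound 2, has both ends at the limit and yields no size. No measured step exchanges furan-2-yl for thiophen-2-yl, and nothing shown leaves the limit. Compound 4 is thus expected to stay at the limit as well, with an estimate of 150000 nM and a range from 60000 nM to 400000 nM. The expected step is a step that the limit leaves unreadable from compound 3 to compound 4, none beyond the scatter.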

Compound 4, half-maximal inhibitory concentration: 39800 nM
Compound 4: middle estimate off by 3.8-fold (0.58 log units), on the high side; measured number outside the range, below it.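

On the saturated ring carbon, furan-2-yl in place of thiophen-2-yl gives an at least 2.5-fold lower number from compound 3 to compound 4 (0.40 log units; beyond the scatter) in this assay, so this position can move the series off the limit. With furan-2-yl held there, the carbonyl carbon also counts: phenyl gives an at least 2.5-fold lower number from compound 2 to compound 4 (0.40 log units; beyond the scatter) against thiophen-2-yl and an at least 2.5-fold lower number from compound 1 to compound 4 (0.40 log units; beyond the scatter) against 3,4,5-trimethoxyphenyl as the group on that carbon. Compound 4 alone carries a number, and the others remain limits: the limit of > 100000 nM in this assay, at which 3 of the 4 values shown sit.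

As far as these compounds go, all three sizes are lower bounds, so the true gaps stay unknown. Open too, from the compounds shown here alone, is whether a pyridin-2-yl or cyclohexyl group on the saturated ring carbon, or a 4-chlorophenyl group on the carbonyl carbon, would lower the number further.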